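The source may hold more compounds than are shown below. What is called first, only, known or untested is meant among the compounds shown, and "the series" means these compounds.

Compound 1, `COc1ccc2c(c1)OC(c1cc(OC)c(OC)c(OC)c1)C(C(=O)N(C)OC)=C2`, in a functional assay for inhibition of nuclear factor NF-kappa-B complex (Homo sapiens); a lower number here means a stronger inhibitor, a higher number a weaker inhibitor: 11700 nM.
Compound 2, `COc1ccc2c(c1)OC(c1cc(OC)c(OC)c(OC)c1)C(C(=O)Nc1ccccc1)=C2`, in this assay: 17500 nM.

Compound 2 carries the larger of the two numbers, but the step of a 1.5-fold higher number from compound 1 to compound 2 (0.17 log units; within the scatter) lies within the scatter, so the two compounds are not separated. Compound 3, `COc1ccc2c(c1)OC(c1cc(OC)c(OC)c(OC)c1)C=C2`, differs from compound 2 by hydrogen in place of phenylcarbamoyl on a double-bonded ring carbon. For the measured compounds named here, the one measured step exchanged one carbonyl substituent for another and barely moved the number; no measured step removes the phenylcarbamoyl group altogether, so its weight is unknown. Compound 3 is therefore expected close to compound 2, a step of a 1.1-fold higher number from compound 2 to compound 3 (0.06 log units; within the scatter). The estimated value for compound 3 is 20000 nM, with a range from 6000 nM to 60000 nM.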

Compound 3, half-maximal inhibitory concentration: 17700 nM
Estimate against measurement, compound 3: 1.1-fold (0.05 log units) above; measured number inside the range.
By their numbers in this assay, from the lowest: compounds 1, 2 and 3 (each within the scatter of the next).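

With hydrogen entering on the double-bonded ring carbon, the phenylcarbamoyl exchange gives a 1.0-fold higher number from compound 2 to compound 3 (0.00 log units; within the scatter) and the methoxy(methyl)carbamoyl exchange gives a 1.5-fold higher number from compound 1 to compound 3 (0.18 log units; within the scatter). In this assay, then, the whole carbonyl substituent can leave this position without separating the compounds, which the exchange of one carbonyl substituent for another could not show. Nothing available bears on why this is so. From the compounds shown here alone, whether a carboxylic acid, an amine or a longer chain on this carbon would separate from hydrogen remains open.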